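Propylsulfanyl in place of methylamino on the monophosphate

This account rests on a few compounds, and the source may have more. Where it says the series, first, only, none or still open, it means among the compounds named here.

Compound 2 `CNc1nc(=O)ccn1[C@@H]1O[C@H](COP(=O)(O)O)[C@@H](O)[C@H]1O` is a monophosphate. In an in vitro functional assay on 1321-N1 cells for agonist activity at P2Y purinoceptor 2 (Homo sapiens), read by scintillation proximity assay and inositol phosphate accumulation (on this read-out higher numbers stand for an effect only at larger amounts of compound and lower numbers for an effect already at smaller amounts), compound 2 gives > 100000 nM, which is a limit of the assay and not a number. Compound 1 `O=c1[nH]c(=S)ccn1[C@@H]1O[C@H](COP(=O)(O)O)[C@@H](O)[C@H]1O` is also a monophosphate; in this assay compound 1 gives > 100000 nM, again a limit. Both rest at the limit of > 100000 nM in this assay, at which 2 of the 3 values shown sit. Compound 3 `CNc1nc(=O)ccn1[C@@H]1O[C@H](COP(=O)(O)OP(=O)(O)O)[C@@H](O)[C@H]1O` carries a diphosphate, and in this assay compound 3 gives 7600 nM. Within the data shown here, the only measured step is an at least 13-fold lower number from compound 2 to compound 3 (1.11 log units; beyond the scatter), and it concerns the phosphate chain, not the group on the ring.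

Compound 4 `CCCSc1nc(=O)ccn1[C@@H]1O[C@H](COP(=O)(O)O)[C@@H](O)[C@H]1O` differs from compound 2 by propylsulfanyl in place of methylamino on an aromatic carbon. No measured step touches this change; the two monophosphates shown, compound 1 and compound 2, both rest at the limit. Compound 4, itself a monophosphate, is therefore expected to stay at or near the limit, with a step that the limit leaves unreadable from compound 2 to compound 4 not beyond the scatter. The estimate for compound 4 in this assay is 150000 nM, within 30000 nM to 1000000 nM.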

Compound 4, half-maximal effective concentration: 4800 nM
For compound 4 the middle estimate is 31-fold (1.49 log units) above the measured one, and the stated range ends above it.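

Propylsulfanyl in place of methylamino on the aromatic carbon between two ring nitrogen atoms gives, in this assay, an at least 20-fold lower number from compound 2 to compound 4 (1.31 log units; beyond the scatter), a large step. The earlier compounds shown here showed a measured step only at the phosphate chain; this one shows that the group at this position can also move a compound off the limit, with the monophosphate left in place. Compound 2 remains a limit of the assay and not a number, so the full size of the step cannot be read: the limit of > 100000 nM in this assay, at which 2 of the 4 values shown sit.

The compounds shown do not separate the sulfur from the longer chain, so propylamino and methylsulfanyl at this position remain the open comparisons. Also open, on these data alone, is whether propylsulfanyl lowers the number on the diphosphate of compound 3 as well.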